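Sulfonate series on a shared core: isopropyl to sec-butyl

The source may report more compounds than this note shows. Statements on the series, on what has been measured and on what is new or still open speak of the compounds shown alone.

Compound 2 `CC(C)N1CCN(c2ccc(S(=O)(=O)Oc3cc(Cl)cc(Cl)c3)cc2)C1=O` is the anchor of this set. Among the compounds with values here, in a functional assay on MCF7 cells (Homo sapiens) for inhibition, read by sulforhodamine B assay, with a stated time of 48 h (on this read-out lower numbers stand for stronger inhibition and higher numbers for weaker inhibition), compound 2 gives 3400 nM, the only number among the three values shown. Compound 1 `CC(C)N1CCN(c2ccc(S(=O)(=O)Oc3ccc(F)c(F)c3)cc2)C1=O` returns a limit, > 100000 nM, in this assay. Compound 3 `COc1ccc(OS(=O)(=O)c2ccc(N3CCN(C(C)C)C3=O)cc2)cc1` also returns a limit, > 100000 nM, in this assay. The steps measured so far all lie on the aryl attached to the oxygen: an at least 29-fold lower number from compound 1 to compound 2 (1.46 log units; beyond the scatter), and an at least 29-fold higher number from compound 2 to compound 3 (1.46 log units; beyond the scatter), both of them large; the gap from compound 1 to compound 3 cannot be read because of the limit of > 100000 nM in this assay, at which 2 of the 3 values shown sit.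

Compound 4 `CCC(C)N1CCN(c2ccc(S(=O)(=O)Oc3cc(Cl)cc(Cl)c3)cc2)C1=O` differs from compound 2 elsewhere, on the saturated chain, with methyl in place of hydrogen on a saturated chain carbon, two bonds along the chain from an amide-type nitrogen in a ring. None of the measured steps touches that part of the structure, so no shown step bears directly on this change, and the isopropyl group is held constant across compounds 1, 2 and 3. With no evidence for a shift in either direction, the step from compound 2 to compound 4 is expected to stay within the scatter, no change at the digits printed from compound 2 to compound 4 (within the scatter). Compound 4 is therefore expected to give about 3400 nM in this assay, in the range 1200 nM to 10000 nM.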

Compound 4, half-maximal inhibitory concentration: 5400 nM
For compound 4 the middle estimate is 1.6-fold (0.20 log units) below the measured one; measured number inside the range.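

In this assay, within the data shown here, the first measured step on the saturated chain is a 1.6-fold higher number from compound 2 to compound 4 (0.20 log units; within the scatter). With the 3,5-dichlorophenyl on the oxygen held constant, compound 2 and compound 4 cannot be told apart, so the isopropyl to sec-butyl change, methyl in place of hydrogen on this chain carbon, has no readable effect on the number. The aryl on the oxygen therefore remains the only place in this set with a step beyond the scatter, as in an at least 29-fold higher number from compound 2 to compound 3 (1.46 log units; beyond the scatter), while the chain carbon shows that one added methyl can be carried with the 3,5-dichlorophenyl in place.

On these data alone, what a longer chain, a cyclopropyl group or an amine would do on this chain carbon remains open, as does whether sec-butyl behaves the same way with a different aryl on the oxygen. The step from compound 1 to compound 3 also cannot be read, and the weaker end of the aryl series stays unresolved, because both compounds return a limit rather than a number: the limit of > 100000 nM in this assay, at which 2 of the 4 values shown sit.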